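A trifluoromethylphenyl in place of the chlorophenyl

The compounds below may be only part of what the source reports. "The series", "measured", "known", "first", "only" and "open" are said of these compounds alone.

Among the measured compounds shown here, all three compounds measured so far share one core and were tested in an assay on isolated protein for inhibition of dual specificity protein phosphatase 3 (Homo sapiens); on this read-out lower numbers stand for stronger inhibition and higher numbers for weaker inhibition. Compound 1, `CCCc1sc(NS(=O)(=O)/C=C/c2ccccc2Cl)nc1-c1ccc(-c2ccccc2)cc1`, gives 82000 nM. Compound 2, `Cc1sc(NS(=O)(=O)/C=C/c2ccc(F)c(F)c2)nc1-c1ccc(Cl)cc1`, gives 43000 nM, and these two numbers sit within the usual scatter of repeated measurements of each other, so they cannot be told apart. Compound 3, `CCc1sc(NS(=O)(=O)/C=C/c2ccc(S(C)(=O)=O)cc2)nc1-c1ccccc1`, reached only a limit of the assay, > 100000 nM, which is the limit of > 100000 nM in this assay, at which 1 of the 3 values shown sits. For the measured compounds named here, all in all, the numbers known so far are large, and no measured pair differs in just one place, so no single step has been measured yet.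

Compound 4, `CCCc1sc(NS(=O)(=O)/C=C/c2ccc(C(F)(F)F)cc2)nc1-c1ccc(-c2ccccc2)cc1`, has not been measured. It differs from compound 1 in one place: 4-(trifluoromethyl)phenyl in place of 2-chlorophenyl on a double-bonded chain carbon bound to a double-bonded chain carbon. Going by the values given here, since every value shown is weak and no step between measured compounds exists to lean on, there is no ground to expect a change beyond the scatter in either direction. Compound 4 is therefore estimated at 80000 nM, with a range from 30000 nM to 200000 nM. The step expected here, a 1.0-fold lower number from compound 1 to compound 4 (0.01 log units; within the scatter), is expected to stay within the scatter, and a result that again reaches only the limit of the assay would not be surprising.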

Compound 4, half-maximal inhibitory concentration: 42000 nM
Compound 4: the middle estimate sits 1.9-fold (0.28 log units) above what was measured, within the range that was stated.
By their numbers in this assay, from the lowest: compounds 4, 2 and 1 (each within the scatter of the next). At a limit, above all of these: compound 3.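

In this assay, among the compounds shown here, the exchange of 2-chlorophenyl for 4-(trifluoromethyl)phenyl gives a 2.0-fold lower number from compound 1 to compound 4 (0.29 log units; within the scatter) and this is the first single change on the shared core that can be read directly. It shows that this place, on a double-bonded chain carbon bound to a double-bonded chain carbon, accepts a quite different substituted phenyl with no change that can be told from the scatter, so the two groups cannot be ranked against each other. For the compounds shown here, the names of the two groups also show that the substituent and its place on the phenyl ring changed together, and nothing measured so far separates those two changes or explains why the number stays where it does.

As far as these compounds go, what remains open is whether a group of another kind on this phenyl ring, such as a carboxylic acid or an amine in place of the trifluoromethyl, would move the number beyond the scatter in either direction. From the compounds shown here alone, it is equally open whether a single change elsewhere on the core, such as a longer chain or a shorter one on the sulfur-bearing ring carbon, would matter more than this one did.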